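This account rests on a few compounds, and the source may have more. Where it says the series, first, only, none or still open, it means among the compounds named here.

Two compounds that share one core differ only in the aryl group carried on a saturated ring carbon. Compound 1, `Fc1ccc(C2CCN(c3ccn4c(CC5CC5)nnc4c3Cl)CC2)c(F)c1`, gives 61.7 nM in a functional assay on CHO cells for agonist activity at metabotropic glutamate receptor 2 (Homo sapiens), read by scintillation counting and GTPgammaS binding, with a stated time of 30 min; a lower number here means that less compound is needed, a higher number that more compound is needed for the effect. Among the compounds with values here, compound 2, `COc1ccccc1C1CCN(c2ccn3c(CC4CC4)nnc3c2Cl)CC1`, gives 20 nM in this assay, the lowest of the two numbers measured so far; the one step observed is a 3.1-fold lower number from compound 1 to compound 2 (0.49 log units; beyond the scatter). Compound 3, `COc1ccc(F)cc1C1CCN(c2ccn3c(CC4CC4)nnc3c2Cl)CC1`, has not yet been measured. It differs from compound 2 by fluoro in place of hydrogen on an aromatic carbon. Within the data shown here, no measured step concerns this kind of change: the single step observed swaps a whole aryl group rather than adding one fluorine to a ring that is otherwise kept, so it offers only a loose guide. A small step is therefore expected, a 1.1-fold higher number from compound 2 to compound 3 (0.04 log units; within the scatter), likely within the scatter. The estimate for compound 3 in this assay is 22 nM, in a range from 8 nM to 60 nM.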

Compound 3, half-maximal effective concentration: 8.2 nM
Beside the measured number, compound 3's estimate is 2.7-fold (0.43 log units) above it, and the stated range covers the measured number.
By their numbers in this assay, from the lowest: compound 3; then compound 2; then compound 1.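

Putting one fluoro on the carbon para to the methoxy group gives a 2.4-fold lower number from compound 2 to compound 3 (0.39 log units; beyond the scatter) in this assay and so shows that this ring position responds to a single-atom change, whereas the earlier pair differed by a whole aryl group. Replacing 2,4-difluorophenyl with 5-fluoro-2-methoxyphenyl gives a 7.5-fold lower number from compound 1 to compound 3 (0.88 log units; beyond the scatter) in the same measurement, the widest gap among the three compounds. Nothing measured here explains why the number falls when the fluoro enters. As far as these compounds go, whether a nitrile, an amine or a longer chain on this same aromatic carbon would lower the number further or raise it remains open. From the compounds shown here alone, it is also open whether fluoro would give a similar step on a ring without the methoxy group.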